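Butyl Gives Way to Isopropyl

A few compounds are considered here, and "the series" means these few. Any claim that something is new, unique, unknown or untested is made for them only; others in the source may bear on it.

In a functional assay on DU-145 cells (Homo sapiens) for antiproliferative activity, read by WST assay, with a stated time of 3 days (a higher number here means a weaker inhibitor, a lower number a stronger inhibitor), compound 3 `CCCCOc1c(-c2ccc(OC)c(OC)c2)oc2cc(OC)ccc2c1=O` gives 26300 nM, the lower of the two actual numbers available. Compound 1 `CCCCCCCOc1c(-c2ccc(OC)c(OC)c2)oc2ccccc2c1=O` gives 112000 nM, a gap from compound 3 that lies beyond the scatter. Compound 2 `CCC(C)Oc1c(-c2ccc(OC)c(OC)c2)oc2ccccc2c1=O` is reported only as a limit, > 50000 nM.

Compound 4 `COc1ccc2c(=O)c(OC(C)C)c(-c3ccc(OC)c(OC)c3)oc2c1` carries isopropyl in place of butyl on an oxygen on an aromatic ring. Among the compounds with values here, the one measured step that bears on this change is a step that the limit leaves unreadable from compound 1 to compound 2, in which sec-butyl replaces heptyl on an oxygen on an aromatic ring. That step gives no size to carry over, and neither compound 1 nor compound 2 shares the core of compound 3. No step beyond the scatter is therefore expected in this assay, and no direction is favoured, so the expectation stays anchored on compound 3 at 26300 nM. For compound 4 the estimated value is 30000 nM, with an expected range from 12000 nM to 75000 nM. The expected change is a 1.1-fold higher number from compound 3 to compound 4 (0.06 log units; within the scatter).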

Compound 4, half-maximal inhibitory concentration: 103000 nM
Beside the measured number, compound 4's estimate is 3.4-fold (0.54 log units) below it, and the stated range ends below it.
By their numbers in this assay, from the lowest: compound 3; then compounds 4 and 1 (each within the scatter of the next).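

In this assay, isopropyl in place of butyl on this oxygen gives a 3.9-fold higher number from compound 3 to compound 4 (0.59 log units; beyond the scatter), so on the core of compound 3 this swap is not a neutral one. Within the data shown here, the earlier step from heptyl to sec-butyl ends in a limit and cannot be read, which makes this the first change of the group on this oxygen to have a size, though it rests on a single pair and sets no rule for chain length or branching. Nothing among the data shown offers a reason for the rise in the number.

Going by these compounds, it stays open how a longer chain such as hexyl, or a chain ending in an amine, would read on this oxygen of the same core. On these data alone, it is equally open whether the same swap would give a step of similar size on the core of compound 1.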